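From Ethoxycarbonyl to Formyl: What to Expect of Compound 4

The source may hold more compounds than are shown below. What is called first, only, known or untested is meant among the compounds shown, and "the series" means these compounds.

Compound 1 `COc1cc(/C=C/C(C)=O)ccc1OCc1cn(-c2ccccc2CO)nn1`: 50300 nM
Compound 2 `COc1cc(/C=C/C(C)=O)ccc1OCc1cn(-c2ccccc2OC)nn1`: 2050 nM
Compound 3 `CCOC(=O)c1ccc(-n2cc(COc3ccc(/C=C/C(C)=O)cc3OC)nn2)cc1`: 59200 nM

In a functional assay on PC-3 cells (Homo sapiens) for antiproliferative activity, read by MTT assay, with a stated time of 48 h (a lower number here means a stronger inhibitor, a higher number a weaker inhibitor), compound 3 gives the highest number of the three; compound 1 sits within the scatter of it, while compound 2 lies far lower. Compound 4 `COc1cc(/C=C/C(C)=O)ccc1OCc1cn(-c2ccc(C=O)cc2)nn1` differs from compound 3 by hydrogen in place of ethoxy on a carbonyl carbon. Among the compounds with values here, no measured step touches this carbonyl carbon. Within the data shown here, the only measured step, a 25-fold lower number from compound 1 to compound 2 (1.39 log units; beyond the scatter), concerns a different group on a different carbon, so it shows only that a small exchange on that part of the shared core can move the numbers strongly, not in which direction here. The expected step is therefore modest, a 1.5-fold lower number from compound 3 to compound 4 (0.17 log units; within the scatter), with wide uncertainty. The estimate for compound 4 is 40000 nM, between 8000 nM and 150000 nM.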

Compound 4, half-maximal inhibitory concentration: 80700 nM
Compound 4: middle estimate off by 2.0-fold (0.30 log units), on the low side, within the range that was stated.
By their numbers in this assay, from the lowest: compound 2; then compounds 1, 3 and 4 (each within the scatter of the next).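

In this assay, within the data shown here, the change from ethoxycarbonyl to formyl gives a 1.4-fold higher number from compound 3 to compound 4 (0.13 log units; within the scatter) and so leaves the number high, the first reading at this carbonyl carbon. The other comparisons agree: a 1.6-fold higher number from compound 1 to compound 4 (0.21 log units; within the scatter) also stays within the scatter, whereas a 39-fold higher number from compound 2 to compound 4 (1.60 log units; beyond the scatter) is large and leaves compound 2 alone at the low end. Nothing available here explains these results. Still open, from the compounds shown here alone, is whether a carboxylic acid in place of ethoxycarbonyl, or an amine on the carbonyl carbon, would bring the number down.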